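Quinone pair: chloro for methyl on the pendant aryl

The compounds below may be only part of what the source reports. "The series", "measured", "known", "first", "only" and "open" are said of these compounds alone.

Of the compounds shown here, two have been measured in a functional assay on cells (Cancer cell lines, Homo sapiens) for cytotoxicity, read by sulforhodamine B assay, with a stated time of 48 h; on this read-out higher numbers stand for weaker inhibition of growth and lower numbers for stronger inhibition of growth. Compound 1 `NS(=O)(=O)c1ccc(-n2nc(-c3ccc(Cl)cc3)cc2-c2cc(O)ccc2O)cc1` carries a hydroquinone on the shared core together with a chlorophenyl; in this assay compound 1 gives 39100 nM. Compound 2 `Cc1ccc(-c2cc(C3=CC(=O)C=CC3=O)n(-c3ccc(S(N)(=O)=O)cc3)n2)cc1` carries the oxidised quinone together with a methylphenyl; in this assay compound 2 gives 100000 nM. Of the two numbers, compound 2 stands at the higher one, and the gap to compound 1 lies beyond the usual scatter of repeated measurements, so compound 2 is the weaker growth inhibitor of the pair.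

Compound 3 `NS(=O)(=O)c1ccc(-n2nc(-c3ccc(Cl)cc3)cc2C2=CC(=O)C=CC2=O)cc1` keeps the quinone and the sulfonamide-bearing aryl of compound 2 and differs from it only by chloro in place of methyl on an aromatic carbon, on a six-membered aromatic ring of carbon only, para to a large group. Among the measured compounds shown here, no measured pair isolates this exchange, so its effect is not established here.

The exchange of one heavy atom for another without change in ring count, donors or acceptors is expected to move the number little; for compound 3 the step of a 1.4-fold lower number from compound 2 to compound 3 (0.15 log units; within the scatter) is expected to stay within or just beyond the scatter, towards stronger inhibition if anything. The estimate for compound 3 in this assay is 70000 nM, with a range from 30000 nM to 150000 nM.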

Compound 3, concentration for total growth inhibition: 71100 nM
Compound 3: middle estimate off by 1.0-fold (0.01 log units), on the low side; low and high end bracket the measured number.
By their numbers in this assay, from the lowest: compounds 1, 3 and 2 (each within the scatter of the next, the first and the last beyond it).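

In this assay the exchange of 4-methylphenyl for 4-chlorophenyl with the quinone held fixed gives a 1.4-fold lower number from compound 2 to compound 3 (0.15 log units; within the scatter) and thus, in this series, does not separate chloro from methyl at this position. With the chlorophenyl held fixed, the exchange of the hydroquinone of compound 1 for the quinone of compound 3 gives a 1.8-fold higher number from compound 1 to compound 3 (0.26 log units; within the scatter) and likewise stays inside the usual scatter, so the gap beyond the scatter between compound 1 and compound 2 appears only where the two compounds differ in both places, and neither single exchange reproduces it. No measurement at hand bears on the cause of either step.

As far as these compounds go, whether the pendant aryl responds at all to a group further from chloro and methyl, such as an amine, a carboxylic acid or a longer alkyl chain in the same place, remains open. Also open, from the compounds shown here alone, is how the hydroquinone behaves with methyl on that ring, which would show whether the exchange of chloro for methyl reads the same on both forms of the shared core.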